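Trifluoromethoxy to Methoxy on a Thioacetate Sulfonamide Core

The source may report more compounds than this note shows. Statements on the series, on what has been measured and on what is new or still open speak of the compounds shown alone.

Compound 1 `CC(=O)SCC(=O)c1ccc(NS(=O)(=O)c2ccc(OC(F)(F)F)cc2)cc1`: 8800 nM
Compound 2 `CC(=O)SCC(=O)c1ccc(NS(=O)(=O)c2ccc(Cl)c(Cl)c2)cc1`: "not determined" (no result reported)

Among the measured compounds shown here, compound 1 carries the only number here: in a functional assay on HCT-116 cells (Homo sapiens) for cytotoxicity (a higher number here means that more compound is needed for the effect, a lower number that less compound is needed), compound 1 gives 8800 nM. In this assay compound 2 gives "not determined" (no result reported), so the two offer no comparison. Compound 3 `COc1ccc(S(=O)(=O)Nc2ccc(C(=O)CSC(C)=O)cc2)cc1` has not been measured. It differs from compound 1 by methyl in place of trifluoromethyl on an oxygen on an aromatic ring. For the measured compounds named here, no measured step of this kind is available, so the step from compound 1 to compound 3 is expected to be small, if anything a slight move toward more compound being needed, and it may stay within the scatter: the expected step is a 1.4-fold higher number from compound 1 to compound 3 (0.13 log units; within the scatter). Compound 3 is accordingly estimated at 12000 nM, with a range from 4000 nM to 40000 nM.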

Compound 3, half-maximal effective concentration: 500 nM
The estimate for compound 3 lay 24-fold (1.38 log units) above the measured number, and the stated range ends above it.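

Measured in this assay the change from trifluoromethoxy to methoxy brings an 18-fold lower number from compound 1 to compound 3 (1.25 log units; beyond the scatter) and so shows that this position on the shared core is sensitive: replacing trifluoromethyl with methyl on this oxygen alone moves the number well beyond the scatter. Nothing available explains the size of this step. As far as these compounds go, with only these two groups compared at this oxygen, it remains open whether the trend continues with an ethyl group or a longer chain, and how a free hydroxyl or an amine in this place would read.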